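Nitro Substitution in a Small Cytotoxic Amidine Series

A few compounds are considered here, and "the series" means these few. Any claim that something is new, unique, unknown or untested is made for them only; others in the source may bear on it.

Measured compounds:
compound 1, `N=C(NCc1ccccc1)[C@@H]1CCC(=O)N1Cc1ccccc1` — 20.7%
compound 2, `COc1ccc(CNC(=N)[C@@H]2CCC(=O)N2Cc2ccccc2)cc1` — 19.5%

In a functional assay on SH-SY5Y cells (Homo sapiens) for cytotoxicity, read by MTT assay, with stated times of 8 h, 30 min and 12 h, tested at 5 uM (a higher number here means a stronger effect of the compound at the concentration tested, a lower number a weaker effect), compound 1 gives 20.7%, and compound 2 gives 19.5%. Compound 1 sits at the top of the two numbers, yet the step of a number 1.2 percentage points lower from compound 1 to compound 2 (within the scatter) does not separate the two compounds, so nothing can be said about an order between them.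

Compound 3, `N=C(NCc1ccccc1)[C@@H]1CCC(=O)N1Cc1ccccc1[N+](=O)[O-]`, is drawn from compound 1 by one change: nitro in place of hydrogen on an aromatic carbon. Within the data shown here, no measured step concerns a nitro group. Among the measured compounds shown here, the single step that exists, a number 1.2 percentage points lower from compound 1 to compound 2 (within the scatter), describes a different group at a different aromatic carbon and stayed within the scatter, so it offers only weak guidance. Lacking any step of size in this series, compound 3 is expected to show a step of a number 0.3 percentage points higher from compound 1 to compound 3 (within the scatter), which is not beyond the scatter. Compound 3 is therefore estimated at 21%, with a range from 8% to 36%.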

Compound 3, a percentage reported as activity, at one concentration (the size of the read-out at that concentration, not a potency): 25.3%
Beside the measured number, compound 3's estimate is 4.3 percentage points below it; the measured number falls inside the stated range.
By their numbers in this assay, from the lowest: compounds 2, 1 and 3 (each within the scatter of the next).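

In this assay, nitro in place of hydrogen on an aromatic carbon, ortho to a large group, gives a number 4.6 percentage points higher from compound 1 to compound 3 (within the scatter) and so leaves no change that can be told apart from the scatter. The earlier pair spoke only of methoxy at a different aromatic carbon, whereas this result shows that a group of 3 heavy atoms can enter at this ortho position of the core of compound 1 without a step beyond the scatter. No supporting data are available to explain the result of compound 3.

The compounds shown leave open whether an amine or a carboxylic acid at this same carbon would also stay within the scatter of compound 1. They also do not tell whether a methoxy group placed here would behave as the nitro group does.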